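Moving the Methylsulfonyl Pyrazole to the Other Ring Carbon

This account rests on a few compounds, and the source may have more. Where it says the series, first, only, none or still open, it means among the compounds named here.

Three measured compounds share one core and differ only in the ring that hangs from it. In a functional assay on MV4-11 cells (Homo sapiens) for antiproliferative activity, with a stated time of 6 days, tested at 1.56 uM (on this read-out lower numbers stand for a weaker effect and higher numbers for a stronger effect at the one concentration tested), compound 3 `CNC(=O)N1CCCc2ccc(NC(=O)c3cccc(-c4ccn(S(C)(=O)=O)n4)c3)cc21` gives 4.03%, which is the second highest of the three numbers, yet compound 1 `CNC(=O)N1CCCc2ccc(NC(=O)c3cccc(-c4ccccc4)c3)cc21`, the phenyl analogue, gives 2.83%, and a number 1.2 percentage points higher from compound 1 to compound 3 (within the scatter). Within the data shown here, the one strong compound is compound 2 `CNC(=O)N1CCCc2ccc(NC(=O)c3cccc(-c4cnn(C)c4)c3)cc21`, which gives 71.2%; a number 68.4 percentage points higher from compound 1 to compound 2 (beyond the scatter), and in the other direction a number 67.2 percentage points lower from compound 2 to compound 3 (beyond the scatter).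

Compound 4 `CNC(=O)N1CCCc2ccc(NC(=O)c3cccc(-c4cnn(S(C)(=O)=O)c4)c3)cc21` differs from compound 3 in a single place: 1-(methylsulfonyl)-1H-pyrazol-4-yl in place of 1-(methylsulfonyl)-1H-pyrazol-3-yl on an aromatic carbon. The step that bears on this is the large one from compound 2 to compound 3, but that step changed two things at once, the point of attachment of the pyrazole and the group on its ring nitrogen. Among the measured compounds shown here, compound 4 keeps the methylsulfonyl group of compound 3 and takes the attachment point of compound 2, so no measured step isolates the change. Because the attachment point of compound 2 went with 71.2%, a rise is plausible, but it is uncertain how much of that number came from the attachment point rather than the methyl group.

Compound 4 is therefore expected to give about 25%, within a wide range from 2% to 70%. The expected step is a number 21 percentage points higher from compound 3 to compound 4 (beyond the scatter), a rise, but with low confidence.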

Compound 4, a percentage reported as inhibition, at one concentration (the size of the read-out at that concentration, not a potency): 1.6%
Estimate against measurement, compound 4: 23.4 percentage points above; measured number outside the range, below it.
By their numbers in this assay, from the lowest: compounds 4, 1 and 3 (each within the scatter of the next); then compound 2.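

With the methylsulfonyl group held fixed, the attachment point of the pyrazole can now be read on its own: in this assay the step is a number 2.4 percentage points lower from compound 3 to compound 4 (within the scatter), so 1-(methylsulfonyl)-1H-pyrazol-4-yl and 1-(methylsulfonyl)-1H-pyrazol-3-yl cannot be told apart on this read-out. With the attachment point held fixed instead, the group on the ring nitrogen can also be read on its own: methylsulfonyl in place of methyl gives a number 69.6 percentage points lower from compound 2 to compound 4 (beyond the scatter), so among these compounds the large loss goes with the swap on the nitrogen and not with the move around the pyrazole. The comparison with the phenyl analogue gives a number 1.2 percentage points lower from compound 1 to compound 4 (within the scatter), which puts this pyrazole level with phenyl, and nothing available here explains why the methylsulfonyl group goes with so low a number.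

The compounds shown leave open how a 1-methyl-1H-pyrazol-3-yl group would read, which would tell whether the attachment point matters when the ring nitrogen carries methyl. Also open, going by these compounds, is how other groups on that nitrogen would fare, such as an ethyl group, an acetyl group or a plain hydrogen.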